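From 2,5-dichlorophenyl to 2-fluoro-5-methylphenyl at the assay limit

The source may hold more compounds than are shown below. What is called first, only, known or untested is meant among the compounds shown, and "the series" means these compounds.

Compound 1 `Cc1ccc(S(=O)(=O)N[C@@H](CC(=O)NC(C)(C)C)C(=O)NCCNC(=O)c2cccc(F)c2)cc1`: > 11100 nM (a limit)
Compound 2 `Cc1ccc(S(=O)(=O)N[C@@H](CC(=O)NC(C)(C)C)C(=O)NCCNC(=O)c2cc(Cl)ccc2Cl)cc1`: > 11100 nM (a limit)

Both compounds were tested in an ADME assay on Karpas-1106P cells (Homo sapiens) for cytotoxicity (a higher number here means that more compound is needed for the effect, a lower number that less compound is needed), and neither gave an exact number. Compound 2 stands at > 11100 nM and this is a limit of the assay, not a measured number. Going by the values given here, the one measured step, a step that the two limits leave unreadable from compound 1 to compound 2, has no readable size. Compound 3 `Cc1ccc(S(=O)(=O)N[C@@H](CC(=O)NC(C)(C)C)C(=O)NCCNC(=O)c2cc(C)ccc2F)cc1` differs from compound 2 in a single group: 2-fluoro-5-methylphenyl in place of 2,5-dichlorophenyl on a carbonyl carbon and the rest of the structure stays the same. Because of the limit of > 11100 nM in this assay, at which 2 of the 2 values shown sit, compound 3 is expected to show no step beyond the scatter in this assay and no direction can be named. It may well be reported as a limit too. For compound 3 the estimated value is 14000 nM with an expected range from 6000 nM to 30000 nM as its ends. The expected step is a step that the limit leaves unreadable from compound 2 to compound 3 and it rests on this estimate alone.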

Compound 3, half-maximal effective concentration: > 11100 nM
Compound 3: only a limit was reported; the forecaster's own chance of this, stated with the estimate: 85%; the middle value does not contradict the limit.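

Compound 3, like compound 1 and compound 2, gives only a limit in this assay, so no new step can be read among them: the limit of > 11100 nM in this assay, at which 3 of the 3 values shown sit.

The compounds shown leave open how the 3-fluorophenyl, 2,5-dichlorophenyl and 2-fluoro-5-methylphenyl groups truly compare in this assay.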